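The source may hold more compounds than are shown below. What is called first, only, known or untested is meant among the compounds shown, and "the series" means these compounds.

Of the compounds shown here, three built on one shared core have been tested in a functional assay on HepG2 cells (Homo sapiens) for antiproliferative activity, read by MTT assay, with a stated time of 24 h; a lower number here means a stronger inhibitor, a higher number a weaker inhibitor. Compound 1 `FC(F)(F)c1ccc(-c2nn(-c3ccccc3)cc2-c2nc3ccccc3[nH]2)cc1`, with a hydrogen on the aromatic nitrogen, gives 6030 nM. Compound 2 `Cc1ccc(-c2nn(-c3ccccc3)cc2-c2nc3ccccc3n2S(=O)(=O)c2ccc(F)cc2)cc1`, which carries a (4-fluorophenyl)sulfonyl group, gives 5060 nM. Compound 3 `COc1ccc(S(=O)(=O)n2c(-c3cn(-c4ccccc4)nc3-c3ccc(C(F)(F)F)cc3)nc3ccccc32)cc1`, which carries a (4-methoxyphenyl)sulfonyl group, gives 370 nM, the lowest number of the three and beyond the scatter from both others.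

The next compound, compound 4 `O=S(=O)(c1ccc(F)cc1)n1c(-c2cn(-c3ccccc3)nc2-c2ccc(C(F)(F)F)cc2)nc2ccccc21`, keeps everything in compound 3 except one group: fluoro in place of methoxy on an aromatic carbon. In words, this is fluoro in place of methoxy on an aromatic carbon, para to a large group.

Within the data shown here, no measured step makes this exchange directly. The closest is the addition of the whole sulfonyl group, which gave a 16-fold lower number from compound 1 to compound 3 (1.21 log units; beyond the scatter), but that step says nothing about the methoxy on its own. Compound 2, at 5060 nM, already has the (4-fluorophenyl)sulfonyl group, yet it also differs from compound 3 elsewhere, so its high number cannot be credited to the fluoro alone. It still points toward a higher number, so a partial loss is the likelier outcome. The expected size of the change is a 3.2-fold higher number from compound 3 to compound 4 (0.51 log units; beyond the scatter), though this rests on thin evidence. The estimate for compound 4 is 1200 nM, with an expected range from 350 nM to 4500 nM.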

Compound 4, half-maximal inhibitory concentration: 2730 nM
The estimate for compound 4 lay 2.3-fold (0.36 log units) below the measured number, and the stated range covers the measured number.
By their numbers in this assay, from the lowest: compound 3; then compounds 4, 2 and 1 (each within the scatter of the next, the first and the last beyond it).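

In this assay, the group at the end of the sulfonyl arm turns out to matter a great deal: fluoro in place of methoxy on the aromatic carbon, para to a large group, gives a 7.4-fold higher number from compound 3 to compound 4 (0.87 log units; beyond the scatter) and so gives back much of the gain seen earlier in a 16-fold lower number from compound 1 to compound 3 (1.21 log units; beyond the scatter) when the whole (4-methoxyphenyl)sulfonyl group was added. Adding the (4-fluorophenyl)sulfonyl group instead yields only a 2.2-fold lower number from compound 1 to compound 4 (0.34 log units; beyond the scatter), so the sulfonyl link alone does not account for the low number of compound 3, and the methoxy is tied to most of that gain, while trifluoromethyl in place of methyl on the other aromatic ring gives a 1.9-fold lower number from compound 2 to compound 4 (0.27 log units; within the scatter) and separates this one pair by no more than ordinary scatter. Nothing available here explains why the methoxy compound stands apart.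

Still open, as far as these compounds go, is whether the oxygen or the methyl of the methoxy carries the effect, which a hydroxy or an ethoxy group at the same place could help to separate. From the compounds shown here alone, it is also open whether an amine there would keep the low number, and whether methyl in place of trifluoromethyl would matter once the methoxy is present.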